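The compounds below may be only part of what the source reports. "The series", "measured", "known", "first", "only" and "open" are said of these compounds alone.

In a functional assay on HT-29 cells (Homo sapiens) for inhibition, read by MTT assay, with a stated time of 48 h (on this read-out higher numbers stand for weaker inhibition and lower numbers for stronger inhibition), compound 1 `COc1ccc(-n2c(SC)nnc2-c2cc(OC)c(OC)c(OC)c2)cc1` gives > 60000 nM as its reading, which is a limit of the assay and not a number. Compound 2 `COc1ccc(-n2c(SCc3ccc(F)cc3)nnc2-c2cc(OC)c(OC)c(OC)c2)cc1` gives 50700 nM and compound 3 `COc1cc(-c2nnc(SCc3ccc(F)cc3)n2-c2ccc(N(C)C)cc2)cc(OC)c1OC` gives 44300 nM as its reading, so these two stand within the scatter of each other. Compound 4 `COc1ccc(NC(=O)CSc2nnc(-c3cc(OC)c(OC)c(OC)c3)n2-c2ccc(N(C)C)cc2)cc1` differs from compound 3 by (4-methoxyphenyl)carbamoyl in place of 4-fluorophenyl on a saturated chain carbon bound to a sulfur. At that carbon the measured step is an at least 1.1-fold lower number from compound 1 to compound 2 (0.07 log units; that floor lies within the scatter) and it is only a floor, while the step on an aromatic carbon is a 1.1-fold lower number from compound 2 to compound 3 (0.06 log units; within the scatter) and it also stays small. No step beyond the scatter is therefore expected in this assay and the estimated step is a 1.8-fold lower number from compound 3 to compound 4 (0.25 log units; within the scatter) at most likely. Compound 4 is expected at 25000 nM with an estimated range of 4000 nM to 60000 nM in this read-out.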

Compound 4, half-maximal inhibitory concentration: 51400 nM
Compound 4: middle estimate off by 2.1-fold (0.31 log units), on the low side, and the stated range covers the measured number.
By their numbers in this assay, from the lowest: compounds 3, 2 and 4 (each within the scatter of the next). At a limit, above all of these: compound 1.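

In this assay, placing (4-methoxyphenyl)carbamoyl in place of 4-fluorophenyl on a saturated chain carbon bound to a sulfur gives a 1.2-fold higher number from compound 3 to compound 4 (0.06 log units; within the scatter). Among the compounds shown here, this position therefore tolerates an exchange that brings in a hydrogen-bond donor and a carbonyl without any step beyond the scatter, which the earlier compounds, carrying only hydrogen or 4-fluorophenyl there, did not show. Compound 1 remains at a limit and not a number: the limit of > 60000 nM in this assay, at which 1 of the 4 values shown sits.

As far as these compounds go, whether an amine, a carboxylic acid or a longer chain on this carbon would move the reading beyond the scatter stays open.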